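Removing the ring methyl: compound 3 to compound 4

The source may report more compounds than this note shows. Statements on the series, on what has been measured and on what is new or still open speak of the compounds shown alone.

Measured so far in a functional assay on HepG2 cells (Homo sapiens) for cytotoxicity, read by MTT assay, with a stated time of 24 h; a lower number here means a stronger inhibitor, a higher number a weaker inhibitor:
compound 1 `CN(C)CCN1CCN(CC(=O)Nc2ccc(-c3nc4cc(F)ccc4o3)cc2)CC1` gives 18800 nM
compound 2 `Cc1cc(-c2nc3cc(F)ccc3o2)ccc1NC(=O)CN1CCN(CCN(C)C)CC1` gives 9460 nM
compound 3 `Cc1cc(-c2nc3ccccc3o2)ccc1NC(=O)CN1CCN(CCN(C)C)CC1` gives 19900 nM

Compound 3 holds the highest number of the three in this assay, but its gap to compound 1 lies within the scatter; only compound 2 is clearly apart, as the step of a 2.1-fold higher number from compound 2 to compound 3 (0.32 log units; beyond the scatter) shows. Compound 4 `CN(C)CCN1CCN(CC(=O)Nc2ccc(-c3nc4ccccc4o3)cc2)CC1` differs from compound 3 by hydrogen in place of methyl on an aromatic carbon. Going by the values given here, the one measured step that bears on this change is its reverse, a 2.0-fold lower number from compound 1 to compound 2 (0.30 log units; within the scatter), which itself stayed within the scatter. Undoing it should give a step of about that size toward a higher number, or none beyond the scatter. The expected step for compound 4 is a 1.5-fold higher number from compound 3 to compound 4 (0.18 log units; within the scatter). Compound 4 is therefore estimated at 30000 nM, with a range from 12000 nM to 75000 nM.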

Compound 4, half-maximal inhibitory concentration: 16300 nM
Beside the measured number, compound 4's estimate is 1.8-fold (0.26 log units) above it; low and high end bracket the measured number.
By their numbers in this assay, from the lowest: compounds 2, 4, 1 and 3 (each within the scatter of the next, the first and the last beyond it).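

In this assay, hydrogen in place of methyl on the aromatic carbon gives a 1.2-fold lower number from compound 3 to compound 4 (0.09 log units; within the scatter), and hydrogen in place of fluoro gives a 1.2-fold lower number from compound 1 to compound 4 (0.06 log units; within the scatter). The methyl change now stands on a second core, and its two steps do not separate beyond the scatter: the same change on two cores in this assay, a 2.0-fold lower number (0.30 log units; within the scatter) from compound 1 to compound 2 and a 1.2-fold higher number (0.09 log units; within the scatter) from compound 4 to compound 3, 2.4-fold (0.38 log units) apart, within the scatter of two such steps. The fluoro change also has two readings that do not separate beyond the scatter: the same change on two cores in this assay, a 2.1-fold higher number (0.32 log units; beyond the scatter) from compound 2 to compound 3 and a 1.2-fold lower number (0.06 log units; within the scatter) from compound 1 to compound 4, 2.4-fold (0.38 log units) apart, within the scatter of two such steps.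

Only hydrogen and methyl have been compared at this position. As far as these compounds go, an amine, a carboxylic acid or a longer chain there remains open in this assay.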